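Moving the fluorine on the phenoxy ring of compound 3

A few compounds are considered here, and "the series" means these few. Any claim that something is new, unique, unknown or untested is made for them only; others in the source may bear on it.

Three compounds share one core, an amide-bearing aryl urea on a piperidine whose saturated carbon carries an aryloxy group, and have been tested in an assay on isolated protein for inhibition of acyl-CoA desaturase 1 (Mus musculus); on this read-out lower numbers stand for stronger inhibition and higher numbers for weaker inhibition. Compound 1 `CNC(=O)c1cccc(NC(=O)N2CCC(Oc3ccccc3Br)CC2)c1` reaches the limit of this assay at < 4 nM. Compound 2 `CNC(=O)c1cccc(NC(=O)N2CCC(Oc3ccccc3OC)CC2)c1` gives 81 nM in this assay. Compound 3 `CNC(=O)c1cccc(NC(=O)N2CCC(Oc3c(F)cccc3Cl)CC2)c1` gives 330 nM in this assay, the highest of the two actual numbers, with compound 2 nearest (a 4.1-fold higher number from compound 2 to compound 3 (0.61 log units; beyond the scatter)). The other measured steps are an at least 20-fold higher number from compound 1 to compound 2 (1.30 log units; beyond the scatter) and an at least 82-fold higher number from compound 1 to compound 3 (1.91 log units; beyond the scatter); the first of these involves the limit described under (the limit of < 4 nM in this assay, at which 1 of the 3 values shown sits).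

Compound 4 `CNC(=O)c1cccc(NC(=O)N2CCC(Oc3cc(F)ccc3Cl)CC2)c1` differs from compound 3 only in the arrangement of the same atoms: 2-chloro-5-fluorophenyl in place of 2-chloro-6-fluorophenyl on an oxygen on a saturated carbon. For the measured compounds named here, none of the measured steps moves a fluorine within an aryl ring while keeping the chlorine; each of them exchanges the whole aryl group or one substituent for another. The measured steps therefore give no direct guide, and the expectation for compound 4 rests only on the observation that all three measured aryloxy variants lie within a broad span. A modest change is expected, a 2.8-fold lower number from compound 3 to compound 4 (0.44 log units; beyond the scatter), so that compound 4 is estimated at 120 nM, within 30 nM to 500 nM.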

Compound 4, half-maximal inhibitory concentration: < 4 nM
Compound 4 ended at the assay's limit (the forecaster's own chance of this, stated with the estimate: 5%); at least 30-fold (1.47 log units) between middle value and limit.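

For the compounds shown here, with the same atoms on the same oxygen, 2-chloro-5-fluorophenyl in place of 2-chloro-6-fluorophenyl gives an at least 82-fold lower number from compound 3 to compound 4 (1.91 log units; beyond the scatter) in this assay, so for this pair the placing of the fluorine alone separates a weak result from one at the limit, which no earlier step could show. The 2-chloro-5-fluorophenyl group also stands clear of the 2-methoxyphenyl group, with an at least 20-fold lower number from compound 2 to compound 4 (1.30 log units; beyond the scatter). The value of compound 4, < 4 nM, is a limit of the assay, as is that of compound 1, so the step joining these two cannot be read: the limit of < 4 nM in this assay, at which 2 of the 4 values shown sit.

On these data alone, how far past the limit compound 1 and compound 4 lie remains open, so the 2-bromophenyl and 2-chloro-5-fluorophenyl groups cannot be ranked against each other. Also open, as far as these compounds go, is whether a methoxy, nitrile or trifluoromethyl group in place of the fluorine of compound 4 would keep its result, and whether a phenyl group carrying the chlorine alone would read like compound 3 or like compound 4.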